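A few compounds are considered here, and "the series" means these few. Any claim that something is new, unique, unknown or untested is made for them only; others in the source may bear on it.

Measured so far:
Compound 1, `O=C(CN(c1nc(Cl)nc2[nH]cnc12)C1CC1)N[C@@H](CC(=O)OCc1ccccc1)C(=O)OCc1ccccc1`, gives 34.7%
Compound 2, `C[C@@H](O)[C@H](NC(=O)CN(c1nc(Cl)nc2[nH]cnc12)C1CC1)C(=O)O`, gives 18.6%

Both numbers come from a functional assay on the whole organism (Tail, strain ICR) with Mus musculus as the target, in the tail flick test, with a stated time of 30 min, at a dose of 25 umol/kg by the oral route; a lower number here means a weaker effect, a higher number a stronger effect of the compound at the dose given. Compound 1 stands higher of the two. The distance between compound 1 and compound 2 is wider than the usual scatter of this kind of measurement, and the order of the two is trustworthy. Among the compounds with values here, no pair of measured compounds differs in a single place, so there is no measured step to lean on.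

The next compound, compound 3, `O=C(CN(c1nc(Cl)nc2[nH]cnc12)C1CC1)N[C@@H](CCC(=O)OCc1ccccc1)C(=O)OCc1ccccc1`, shares the core of compound 1 and differs from it in one place: (benzyloxycarbonyl)methyl in place of benzyloxycarbonyl on a saturated chain carbon, two bonds along the chain from an amide-type nitrogen and a carbonyl carbon. This is a chain that has grown by one saturated carbon, with the same ring and the same ester at its end.

Within the data shown here, with no measured step of this type available, the expectation rests on compound 1 alone. The change is expected to move the read-out only a little, if at all, so the step of a number 4.7 percentage points lower from compound 1 to compound 3 (within the scatter) is estimated to stay within the scatter, perhaps leaning slightly downward. For compound 3 the estimate in this assay is 30%, with a likely range from 12% to 50%.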

Compound 3, a percentage reported as activity, at one dose (the size of the read-out at that dose, not a potency): 52.8%
Compound 3: the middle estimate sits 22.8 percentage points below what was measured; measured number above the stated range.
By their numbers in this assay, from the lowest: compound 2; then compound 1; then compound 3.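

In this assay, within the data shown here, this is the first measured view of the saturated chain carbon, two bonds along the chain from an amide-type nitrogen and a carbonyl carbon: replacing benzyloxycarbonyl with (benzyloxycarbonyl)methyl gives a number 18.1 percentage points higher from compound 1 to compound 3 (beyond the scatter) and so shows that the read-out responds to the length of this chain. Compound 1 and compound 2 differ in more than one place, so their gap could not show this, whereas here a single added saturated carbon, with the same ring and the same ester at the chain end, is enough to produce a step larger than the usual scatter. The data shown offer no measurement that explains why the longer chain gives the higher number.

Going by these compounds, with only these two chain lengths compared, it remains open whether a longer chain, such as 3-(benzyloxycarbonyl)propyl, would raise the read-out further or lower it again. On these data alone, it is also open whether the benzyl ester itself is needed at the chain end, or whether an amine or an amide there would keep the effect at this dose.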